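The compounds below may be only part of what the source reports. "The series", "measured", "known", "first", "only" and "open" are said of these compounds alone.

Measured in a physicochemical assay for solubility, read by spectrophotometry, in phosphate buffer, with a stated time of 18 h, at pH 7.4; a higher number here means a more soluble compound, a lower number a less soluble compound:
compound 1 `CCc1ccc(-c2nc3c(c(C)nn3-c3ccccc3)c(-c3ccccc3C#N)c2C#N)cc1`: 2400 nM
compound 2 `CCc1ccc(-c2nc3c(c(C)nn3-c3ccccc3)c(-c3ccccc3I)c2C#N)cc1`: 8500 nM
compound 3 `CCc1ccc(-c2nc3c(c(C)nn3-c3ccccc3)c(-c3ccccc3)c2C#N)cc1`: 47000 nM

Of these three, compound 3 stands highest, at 47000 nM. Compound 4 `C#Cc1ccccc1-c1c(C#N)c(-c2ccc(CC)cc2)nc2c1c(C)nn2-c1ccccc1` carries ethynyl in place of hydrogen on an aromatic carbon, ortho to a large group: ethynyl in place of hydrogen on an aromatic carbon. Among the measured compounds shown here, two measured steps bear on this change, both replacing a group with hydrogen on an aromatic carbon. Cyano leaves in a 20-fold higher number from compound 1 to compound 3 (1.29 log units; beyond the scatter), a large step, and iodo leaves in a 5.5-fold higher number from compound 2 to compound 3 (0.74 log units; beyond the scatter), a modest one. Both lie beyond the scatter. Read backwards, each puts a group in place of hydrogen and lowers the number, so a modest drop is expected in this assay. The expected step is a 5.9-fold lower number from compound 3 to compound 4 (0.77 log units; beyond the scatter). Compound 4 is estimated at 8000 nM, within a range of 2500 nM to 25000 nM.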

Compound 4, solubility: 46000 nM
Estimate against measurement, compound 4: 5.8-fold (0.76 log units) below; the whole stated range lies below it.
By their numbers in this assay, from the lowest: compound 1; then compound 2; then compounds 4 and 3 (each within the scatter of the next).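

In this assay the step of a 1.0-fold lower number from compound 3 to compound 4 (0.01 log units; within the scatter) shows that a group in place of hydrogen, ortho to a large group, need not lower the number, as cyano and iodo did. With a 5.4-fold higher number from compound 2 to compound 4 (0.73 log units; beyond the scatter) and a 19-fold higher number from compound 1 to compound 4 (1.28 log units; beyond the scatter) on record, the group that enters at this place matters, not merely the presence of one. Nothing shown explains why ethynyl parts from iodo and cyano here.

Going by these compounds, it remains open whether an amine, a carboxylic acid or a longer chain at this place would stay with ethynyl and hydrogen or fall toward iodo and cyano.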